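Series notes: piperidine ring methylation, compound 3 to compound 4

The compounds below may be only part of what the source reports. "The series", "measured", "known", "first", "only" and "open" are said of these compounds alone.

Measured so far:
compound 1 `COc1cc2c(Oc3ccc(NC(=O)c4nn(-c5ccccc5C)c(=O)cc4C)cc3F)ccnc2cc1OCCCN1CCC(C)CC1`: 2260 nM
compound 2 `COc1cc2c(Oc3ccc(NC(=O)c4nn(-c5ccccc5C(F)(F)F)c(=O)cc4C)cc3F)ccnc2cc1OCCCN1CCC(C)CC1`: 200 nM
compound 3 `COc1cc2c(Oc3ccc(NC(=O)c4nn(-c5ccccc5OC(F)(F)F)c(=O)cc4C)cc3F)ccnc2cc1OCCCN1CCCCC1`: 230 nM

All values are from a functional assay on NCI-H460 cells (Homo sapiens) for inhibition, read by MTT assay, with a stated time of 72 h; a higher number here means a weaker inhibitor, a lower number a stronger inhibitor. Compound 3 sits close to compound 2, the two values lying within the scatter of each other, and well apart from compound 1, which gives a clearly higher number.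

Compound 4 `COc1cc2c(Oc3ccc(NC(=O)c4nn(-c5ccccc5OC(F)(F)F)c(=O)cc4C)cc3F)ccnc2cc1OCCCN1CCC(C)CC1` differs from compound 3 by methyl in place of hydrogen on a saturated ring carbon. For the measured compounds named here, the one measured step, an 11-fold lower number from compound 1 to compound 2 (1.05 log units; beyond the scatter), concerns a different position and does not bear on this change. Going by the values given here, no pair in the set isolates the ring methyl, so there is no basis for expecting a shift beyond the scatter in this assay.

The step of no change at the digits printed from compound 3 to compound 4 (within the scatter) is therefore estimated as essentially flat. Compound 4 is expected to give 230 nM, with a range of 100 nM to 520 nM.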

Compound 4, half-maximal inhibitory concentration: 290 nM
Estimate against measurement, compound 4: 1.3-fold (0.10 log units) below; measured number inside the range.
By their numbers in this assay, from the lowest: compounds 2, 3 and 4 (each within the scatter of the next); then compound 1.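

In this assay the change from piperidin-1-yl to 4-methylpiperidin-1-yl does not separate the pair (a 1.3-fold higher number from compound 3 to compound 4 (0.10 log units; within the scatter)), so this ring carbon takes a methyl without a shift beyond the scatter when trifluoromethoxy is present. With 4-methylpiperidin-1-yl held constant, trifluoromethoxy and trifluoromethyl are also not separated (a 1.5-fold higher number from compound 2 to compound 4 (0.16 log units; within the scatter)), whereas trifluoromethoxy in place of methyl gives a step beyond the scatter (a 7.8-fold lower number from compound 1 to compound 4 (0.89 log units; beyond the scatter)). No measurement on hand accounts for these steps.

Going by these compounds, whether the ring methyl step holds with trifluoromethyl or methyl on the aromatic carbon remains open. Also open, on these data alone, is how a hydroxyl or a dimethylamino group on that ring carbon would compare.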